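Butyl-bearing amide chain on the ethyl carbamate lead

The source may report more compounds than this note shows. Statements on the series, on what has been measured and on what is new or still open speak of the compounds shown alone.

Measured in a functional assay on the whole organism for inhibition, with Mus musculus as the target; on this read-out higher numbers stand for an effect only at larger amounts of compound and lower numbers for an effect already at smaller amounts:
- compound 1 `Cc1ccc(C2CN(C)Cc3c(N)cccc32)cc1`: 1.6 mg/kg
- compound 2 `CCCCNC(=O)Nc1cccc2c1CN(C)CC2c1ccc(Cl)cc1`: 44 mg/kg
- compound 3 `CCOC(=O)Nc1cccc2c1CN(C)CC2c1ccccc1`: 3.2 mg/kg

Compound 3, at 3.2 mg/kg, lies within the usual scatter of compound 1 at 1.6 mg/kg. The same value is separated by more than the scatter from compound 2, whose 44 mg/kg is the higher number. Compound 3 therefore sits with compound 1, clear of compound 2.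

The next entry is compound 4 `CCCCNCCC(=O)Nc1cccc2c1CN(C)CC2c1ccccc1`, not yet measured. It keeps the core of compound 3 and the carbonyl, and replaces the group on that carbonyl carbon: 2-(butylamino)ethyl in place of ethoxy on a carbonyl carbon. For the measured compounds named here, no pair of measured compounds differs in one place only, so the series offers no direct precedent for this change.

Going by the values given here, the nearest guide is compound 2 at 44 mg/kg, the only measured compound with a butyl chain, although it differs from compound 3 in more than one place. On that thin basis, a shift toward a higher number is expected in this assay, and the expected size is a 4.4-fold higher number from compound 3 to compound 4 (0.64 log units; beyond the scatter). The estimate for compound 4 is 14 mg/kg, with an expected range of 4 mg/kg to 50 mg/kg.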

Compound 4, dose for half-maximal effect: about 46 mg/kg
Estimate against measurement, compound 4: 3.3-fold (0.52 log units) below; the measured number falls inside the stated range.
By their numbers in this assay, from the lowest: compounds 1 and 3 (each within the scatter of the next); then compounds 2 and 4 (each within the scatter of the next).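

In this assay, for the compounds shown here, the change of ethoxy to 2-(butylamino)ethyl, on a carbonyl carbon whose other neighbour is an amide-type nitrogen, gives a 14-fold higher number from compound 3 to compound 4 (1.16 log units; beyond the scatter) and is the first step that can be read across one place. This position is therefore not indifferent to the group on the carbonyl, and the carbamate of compound 3 cannot be exchanged for this amino-bearing chain without a large move toward a higher number. The step bundles several differences, as the oxygen leaves, a nitrogen with a hydrogen-bond donor enters and the group grows from 3 to 7 heavy atoms, and no measurement here bears on which of them accounts for the size of the step.

The compounds shown leave open whether the butyl end, the amine nitrogen or the loss of the ethoxy oxygen carries the step. A plain hexyl chain on the same carbonyl carbon, or a shorter 2-(methylamino)ethyl group, would begin to separate these contributions.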